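The source may hold more compounds than are shown below. What is called first, only, known or untested is meant among the compounds shown, and "the series" means these compounds.

Two compounds share one core that carries two 4-fluorophenyl groups on a single ring atom, and they differ only in the group on a carbon with a double bond to nitrogen. Compound 1 `OCc1cccc(C2=NC(c3ccc(F)cc3)(c3ccc(F)cc3)CN2)c1` carries 3-(hydroxymethyl)phenyl there, and in an assay on LM cells for displacement of a labelled ligand from Neuropeptide Y receptor type 5 (Homo sapiens) (a higher number here means a weaker inhibitor, a lower number a stronger inhibitor), compound 1 gives 59 nM. Compound 2 `Fc1ccc(C2(c3ccc(F)cc3)CNC(c3ccsc3)=N2)cc1` carries thiophen-3-yl instead, and in this assay compound 2 gives 93 nM. Within the data shown here, the single step measured so far, a 1.6-fold higher number from compound 1 to compound 2 (0.20 log units; within the scatter), shows that these two numbers lie within the scatter of each other, so compound 2 cannot be told apart from compound 1. Compound 3 `Fc1ccc(C2(c3ccc(F)cc3)CNC(c3cccnc3)=N2)cc1` is not yet measured; it differs from compound 2 by pyridin-3-yl in place of thiophen-3-yl on a carbon with a double bond to nitrogen. Among the measured compounds shown here, only that one step bears on this change, and it stayed within the scatter, so a further exchange of the aromatic group on that carbon is expected to move the number little. In this assay compound 3 is therefore estimated at 100 nM, with a range from 35 nM to 300 nM. The expected step of a 1.1-fold higher number from compound 2 to compound 3 (0.03 log units; within the scatter) amounts to nothing beyond the scatter.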

Compound 3, half-maximal inhibitory concentration: 7.2 nM
Beside the measured number, compound 3's estimate is 14-fold (1.14 log units) above it; the measured number lies below the stated range.
By their numbers in this assay, from the lowest: compound 3; then compounds 1 and 2 (each within the scatter of the next).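

The carbon with a double bond to nitrogen is not as indifferent to its aromatic group as the first pair suggested: in this assay, pyridin-3-yl gives a 13-fold lower number from compound 2 to compound 3 (1.11 log units; beyond the scatter) and an 8.2-fold lower number from compound 1 to compound 3 (0.91 log units; beyond the scatter), both beyond the scatter. The exchange from thiophen-3-yl replaces a five-membered aromatic ring with a six-membered one and sulfur with nitrogen, while the counts of hydrogen-bond donors and acceptors stay the same, so those counts do not separate compound 2 from compound 3. Nothing available here explains the gain in binding.

The compounds shown leave open whether the lower number goes with the ring nitrogen, its place in the ring or the six-membered ring itself. Unsubstituted phenyl and pyridin-4-yl on the same carbon would help to separate these possibilities.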